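From methyl to trifluoromethyl on the shared core

A few compounds are considered here, and "the series" means these few. Any claim that something is new, unique, unknown or untested is made for them only; others in the source may bear on it.

In an ADME assay on Vero 76 cells (Chlorocebus sabaeus) for cytotoxicity, read by MTT assay, with a stated time of 96 h (on this read-out higher numbers stand for lower toxicity in this test and lower numbers for higher toxicity in this test), compound 3 `Cc1ccc(NCc2cn(-c3ccccc3)nc2-c2ccccc2)cc1` gives > 100000 nM, which is a limit of the assay and not a number. The next compound, compound 4 `FC(F)(F)c1ccc(NCc2cn(-c3ccccc3)nc2-c2ccccc2)cc1`, differs from it as follows: trifluoromethyl in place of methyl on an aromatic carbon, with trifluoromethyl in place of methyl on an aromatic carbon.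

Going by the values given here, one measured step bears on this place: an at least 1.9-fold higher number from compound 1 to compound 3 (0.28 log units; that floor lies within the scatter), with methyl in place of bromo on an aromatic carbon. Its starting point, compound 1 `Brc1ccc(NCc2cn(-c3ccccc3)nc2-c2ccccc2)cc1`, gives 52000 nM. Because the floor of that step lies within the scatter, it sets no firm size for a change here. Compound 4 shares a trifluoromethyl group with compound 2 `FC(F)(F)c1ccc(NCc2cn(-c3ccccc3)nc2-c2ccc(C(F)(F)F)cc2)cc1`, which gives 26000 nM. The values of compound 1 and compound 2 lie within the scatter of each other, and both are numbers rather than limits.

A move to a lower number in this assay is therefore expected, though its size is uncertain. The expected step is an at least 2.2-fold lower number from compound 3 to compound 4 (0.34 log units; beyond the scatter). For compound 4 the estimated value is 45000 nM, with an expected range from 18000 nM to 100000 nM.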

Compound 4, half-maximal cytotoxic concentration: 17000 nM
Beside the measured number, compound 4's estimate is 2.6-fold (0.42 log units) above it, and the stated range ends above it.
By their numbers in this assay, from the lowest: compounds 4, 2 and 1 (each within the scatter of the next, the first and the last beyond it). At a limit, above all of these: compound 3.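

On the aromatic carbon para to a large group, trifluoromethyl in place of methyl brings the reading to a number (an at least 5.8-fold lower number from compound 3 to compound 4 (0.76 log units; beyond the scatter)), though the size of this step is only a floor: the limit of > 100000 nM in this assay, at which 1 of the 4 values shown sits. Trifluoromethyl in place of bromo at the same carbon also gives a lower number (a 3.1-fold lower number from compound 1 to compound 4 (0.49 log units; beyond the scatter)), so at this position trifluoromethyl separates from both of the other groups shown. The trifluoromethyl elsewhere on the shared core, the single difference in the remaining pair, leaves the reading within the scatter (a 1.5-fold lower number from compound 2 to compound 4 (0.18 log units; within the scatter)).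

From the compounds shown here alone, how an amine, a carboxylic acid or a longer chain on this carbon would read in this assay remains open. Also open, going by these compounds, is how far the methyl compound lies beyond its limit, so the full size of the methyl to trifluoromethyl step stays unknown.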